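Methoxy to Hydroxy: Expected Cytotoxicity of Compound 3

The compounds below may be only part of what the source reports. "The series", "measured", "known", "first", "only" and "open" are said of these compounds alone.

Of the compounds shown here, two have been measured in a functional assay on HaCaT cells (Homo sapiens) for cytotoxicity, read by ELISA and LDH release, with a stated time of 6 h, tested at 20 ug/mL; a lower number here means a stronger effect, a higher number a weaker effect of the compound at the concentration tested. Compound 1 `C=C1C(=O)O[C@H](C2=C(C)C(O)CC2=O)[C@@H]1CCC(C)=O` gives 5%, and compound 2 `C=C1C(=O)O[C@H](C2=C(C)[C@@H](OC)CC2=O)[C@@H]1CCC(C)=O` gives 5%, level with compound 1 at the digits shown and within the scatter. Compound 3 `C=C1C(=O)O[C@H](C2=C(C)[C@@H](O)CC2=O)[C@@H]1CCC(C)=O` has not yet been measured. Compared with compound 2, the change is hydrogen in place of methyl on an oxygen on a saturated carbon; said one bond further out, a methoxy becomes a hydroxy. Because compound 1 gives 5% and compound 2 gives 5%, no step beyond the scatter is expected for compound 3. The expected value for compound 3 is 5%, ranging from 0% to 15%, which means an expected step of no change at the digits printed from compound 2 to compound 3 (within the scatter), none beyond the scatter.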

Compound 3, a percentage reported as activity, at one concentration (the size of the read-out at that concentration, not a potency): 11%
Estimate against measurement, compound 3: 6 percentage points below; low and high end bracket the measured number.
By their numbers in this assay, from the lowest: compounds 1, 2 and 3 (each within the scatter of the next).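

Going from methoxy to hydroxy on this saturated ring carbon gives, in this assay, a number 6 percentage points higher from compound 2 to compound 3 (within the scatter), so with or without the methyl on this oxygen, the read-out stays within the scatter. A second comparison gives a number 6 percentage points higher from compound 1 to compound 3 (within the scatter), and a single thing separates the pair: the fact that one of compounds 1 and 3 is drawn with a defined configuration and the other without, at the place where they differ

Going by these compounds, whether a longer chain on this oxygen, such as ethoxy, or an amine at this carbon would shift the read-out beyond the scatter remains open. The compounds shown also leave open how the opposite configuration at this carbon would read.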